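Hydroxy removal on the methoxyphenyl ring of compound 2

The compounds below may be only part of what the source reports. "The series", "measured", "known", "first", "only" and "open" are said of these compounds alone.

Compound 2 `COc1ccc(-n2cc(-c3ccc(OC)c(O)c3)nn2)cc1` is the starting point of this step. In a functional assay on MDA-MB-231 cells (Homo sapiens) for cytotoxicity, read by MTT assay (a lower number here means a stronger inhibitor, a higher number a weaker inhibitor), compound 2 returns only a limit, > 10000 nM. Compound 1 `COc1ccc(-c2cn(-c3ccc(OC(F)(F)F)cc3)nn2)cc1O`, carrying trifluoromethyl rather than methyl on an oxygen on an aromatic ring, also gives only a limit in this assay, > 10000 nM. Compound 3 `COc1ccc(-c2cn(-c3ccc(OC)c(OC)c3)nn2)cc1O`, with methoxy in place of hydrogen on an aromatic carbon, gives a limit in this assay as well, > 100 nM. Both flanking steps, a step that the two limits leave unreadable from compound 1 to compound 2 and a step that the two limits leave unreadable from compound 2 to compound 3, are therefore unreadable: two values sit at the limit of > 10000 nM in this assay, at which 2 of the 3 values shown sit, and one at the limit of > 100 nM in this assay, at which 1 of the 3 values shown sits, so no size or direction can be taken from them.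

Compound 4 `COc1ccc(-c2cn(-c3ccc(OC)cc3)nn2)cc1` differs from compound 2 by hydrogen in place of hydroxy on an aromatic carbon. Among the measured compounds shown here, no measured step in this assay involves a hydroxy, and the two unreadable steps give no gradient, so the only anchor is the limit of compound 2 itself. Compound 4 is expected to remain weak in this assay, estimated at 20000 nM with a range from 5000 nM to 100000 nM. The step that the limit leaves unreadable from compound 2 to compound 4 is accordingly expected to be within the scatter, with a high chance that only a limit is reported again.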

Compound 4, half-maximal inhibitory concentration: > 100 nM
Compound 4 gave a limit, no number; the forecaster's own chance of this, stated with the estimate: 80%; the middle value lies beyond the limit too.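

Compound 2 and compound 4 both return only limits in this assay, so the step between them, hydrogen in place of hydroxy on an aromatic carbon, cannot be read. The compounds shown leave open whether this change has any effect on the read-out, in size or direction.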